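Changing the ring on the carbonyl of compound 3

A few compounds are considered here, and "the series" means these few. Any claim that something is new, unique, unknown or untested is made for them only; others in the source may bear on it.

In a functional assay on MDA-MB-231 cells (Homo sapiens) for antiproliferative activity, read by MTT assay, with a stated time of 24 h (on this read-out higher numbers stand for weaker inhibition and lower numbers for stronger inhibition), compound 1 `O=C(O)CC(NS(=O)(=O)c1cccc([N+](=O)[O-])c1)c1ccccc1` returns > 100000 nM as its result, which is a limit of the assay and not a number. Compound 2 `O=C(O)CC(NC(=O)c1ccc(F)cc1)c1ccc(Cl)cc1Cl` gives 58300 nM in this assay as its half-maximal inhibitory concentration. Compound 3 `O=C(O)CC(NC(=O)c1cccc(Br)c1)c1ccc(Cl)cc1Cl` gives 82500 nM in this assay and so stands level with compound 2 once the usual scatter is allowed for.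

Compound 4 `O=C(O)CC(NC(=O)c1ccc(Cl)cc1Cl)c1ccc(Cl)cc1Cl` has not been measured yet. The structural change is 2,4-dichlorophenyl in place of 3-bromophenyl on a carbonyl carbon and it puts 2,4-dichlorophenyl in place of 3-bromophenyl on a carbonyl carbon. Within the data shown here, one measured step bears on this, a swap on the same carbonyl carbon: a 1.4-fold higher number from compound 2 to compound 3 (0.15 log units; within the scatter) is all that it moved the number. No shift beyond the scatter is therefore expected in this assay and the estimated change is only a 1.2-fold lower number from compound 3 to compound 4 (0.07 log units; within the scatter) in size. The estimate for compound 4 is 70000 nM with an expected range from 32000 nM to 100000 nM around it.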

Compound 4, half-maximal inhibitory concentration: 49200 nM
Estimate against measurement, compound 4: 1.4-fold (0.15 log units) above; the measured number falls inside the stated range.
By their numbers in this assay, from the lowest: compounds 4, 2 and 3 (each within the scatter of the next). At a limit, above all of these: compound 1.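

With compound 4, the carbonyl carbon has now carried three different halogen-bearing phenyl rings. In this assay, both new steps, a 1.7-fold lower number from compound 3 to compound 4 (0.22 log units; within the scatter) and a 1.2-fold lower number from compound 2 to compound 4 (0.07 log units; within the scatter), stay within the usual scatter, so 2,4-dichlorophenyl, with its two chlorine atoms, stands level with the single-halogen rings 4-fluorophenyl and 3-bromophenyl. No measurement shown here bears on why these three compounds stand level.

As far as these compounds go, the rings compared at this place differ only in their halogens, so it remains open whether an amine, a carboxylic acid or a methoxy group on the ring would move the number beyond the scatter. From the compounds shown here alone, it is also open whether any change at this place can bring the number far down from where these three compounds stand.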